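The source may report more compounds than this note shows. Statements on the series, on what has been measured and on what is new or still open speak of the compounds shown alone.

Compound 1 `C=CC(=O)Nc1cc(Nc2ncc3ncn(-c4ccc(C(C)C)cc4)c3n2)c(OC)cc1N(C)CCN(C)C`: in an ADME assay on HT-29 cells (Homo sapiens) for cytotoxicity, read by MTT assay, with a stated time of 72 h (on this read-out higher numbers stand for weaker inhibition and lower numbers for stronger inhibition), compound 1 gives 15300 nM. Compound 2 `C=CC(=O)Nc1cc(Nc2ncc3ncn(-c4ccc(F)c(Br)c4)c3n2)c(OC)cc1N(C)CCN(C)C`: in this assay compound 2 gives 3640 nM.

Among the compounds with values here, compound 2 holds the lower of the two numbers, with compound 1 the only neighbour. Compound 3 `C=CC(=O)Nc1cc(Nc2ncc3ncn(C4CCCC4)c3n2)c(OC)cc1N(C)CCN(C)C` differs from compound 2 by cyclopentyl in place of 3-bromo-4-fluorophenyl on an aromatic nitrogen. Within the data shown here, the only step that bears on this change is a 4.2-fold lower number from compound 1 to compound 2 (0.62 log units; beyond the scatter), which shows that the group on that aromatic nitrogen moves the number modestly. Among the measured compounds shown here, no measured step exchanges an aryl for a cycloalkyl there, so the direction stays open. The estimate for compound 3 is a modest rise of a 1.8-fold higher number from compound 2 to compound 3 (0.25 log units; within the scatter), giving 6500 nM within 1500 nM to 28000 nM.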

Compound 3, half-maximal inhibitory concentration: 20900 nM
For compound 3 the middle estimate is 3.2-fold (0.51 log units) below the measured one, within the range that was stated.
By their numbers in this assay, from the lowest: compound 2; then compounds 1 and 3 (each within the scatter of the next).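

In this assay cyclopentyl in place of 3-bromo-4-fluorophenyl on the aromatic nitrogen gives a 5.7-fold higher number from compound 2 to compound 3 (0.76 log units; beyond the scatter) and so settles the direction that was open for this exchange. Set against 4-isopropylphenyl, the same cyclopentyl gives a 1.4-fold higher number from compound 1 to compound 3 (0.14 log units; within the scatter) and so no order between those two, which leaves 3-bromo-4-fluorophenyl alone apart among the three groups. Nothing measured here explains this. Open, on these data alone, is whether the bromine or the fluorine carries that separation, and how a piperidine ring or a phenyl bearing an amine would read on this nitrogen.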